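Chain lengthening on the shared core: working notes

The source may hold more compounds than are shown below. What is called first, only, known or untested is meant among the compounds shown, and "the series" means these compounds.

Measured so far:
compound 1 `CN(C)C(=O)c1cc2cnc(Nc3ccc(S(=O)(=O)NCCCCCN=C=S)cc3)nc2n1C1CCCC1` gives 102%
compound 2 `CN(C)C(=O)c1cc2cnc(Nc3ccc(S(=O)(=O)NCCCCCCN=C=S)cc3)nc2n1C1CCCC1` gives 101%
compound 3 `CN(C)C(=O)c1cc2cnc(Nc3ccc(C(=O)NCCCCN=C=S)cc3)nc2n1C1CCCC1` gives 102%

All three numbers come from a functional assay on A549 cells (Homo sapiens) for inhibition, read by CCK-8 assay, with a stated time of 72 h, tested at 10 uM; a higher number here means a stronger effect of the compound at the concentration tested, a lower number a weaker effect. Compound 1 and compound 2 share one core; compound 3 carries a different one, and the difference between the two cores is a group of 10 heavy atoms (6 carbon, 2 nitrogen, 1 oxygen, 1 sulfur; no ring) in place of a group of 12 heavy atoms (6 carbon, 2 nitrogen, 2 oxygen, 2 sulfur; no ring), on an aromatic carbon. That exchange made no change at the digits printed from compound 1 to compound 3 (within the scatter), so the two cores sit level at this concentration.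

Within the first core, compound 1 and compound 2 differ by a group of 4 heavy atoms (2 carbon, 1 nitrogen, 1 sulfur; no ring) in place of a group of 3 heavy atoms (1 carbon, 1 nitrogen, 1 sulfur; no ring), on a saturated chain carbon, five bonds along the chain from a sulfonamide nitrogen. The step was a number 1 percentage points lower from compound 1 to compound 2 (within the scatter). Compound 4 `CN(C)C(=O)c1cc2cnc(Nc3ccc(C(=O)NCCCCCN=C=S)cc3)nc2n1C1CCCC1` has not been measured. It differs from compound 3 by a group of 4 heavy atoms (2 carbon, 1 nitrogen, 1 sulfur; no ring) in place of a group of 3 heavy atoms (1 carbon, 1 nitrogen, 1 sulfur; no ring), on a saturated chain carbon, four bonds along the chain from an amide-type nitrogen. For the measured compounds named here, this is the same kind of change as the one from compound 1 to compound 2, not the same: there the place was five bonds along the chain from a sulfonamide nitrogen, here it is four bonds along the chain from an amide-type nitrogen.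

Compound 3 and compound 1 are level at the digits printed, and the one lengthening already measured left the read-out unchanged within the scatter. On that basis the step from compound 3 to compound 4 is expected to be a number 1 percentage points lower from compound 3 to compound 4 (within the scatter). Compound 4 is therefore estimated at 101% in this assay, with a range from 92% to 108% that rests on the step of a number 1 percentage points lower from compound 1 to compound 2 (within the scatter) and on the near-complete inhibition of compound 3 at 102%.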

Compound 4, a percentage reported as inhibition, at one concentration (the size of the read-out at that concentration, not a potency): 100%
Compound 4: the middle estimate sits 1 percentage points above what was measured; the range from low to high includes it.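

In this assay the exchange of the group of 3 heavy atoms for the group of 4 heavy atoms reads the same on both cores: the same change on two cores in this assay, a number 1 percentage points lower (within the scatter) from compound 1 to compound 2 and a number 2 percentage points lower (within the scatter) from compound 3 to compound 4, 1 percentage points apart, within the scatter of two such steps.

On the core of compound 3 the lengthening alone gives a number 2 percentage points lower from compound 3 to compound 4 (within the scatter), and the step that also exchanges the core gives a number 2 percentage points lower from compound 1 to compound 4 (within the scatter), so in this pair of cores the change carries over without a step beyond the scatter. This does not show that the change is neutral for potency: compound 4 gives 100%, the other three compounds stand at similarly near-complete inhibition, and a percentage at one concentration can hide differences that a full concentration series might separate.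

On these data alone, what remains open is how these compounds would separate at lower concentrations, where the read-out is no longer close to complete inhibition. Also open, as far as these compounds go, is whether the same agreement between cores would hold for a longer chain, or for an amine or a carboxylic acid in place of the group of 4 heavy atoms.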